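The source may hold more compounds than are shown below. What is called first, only, known or untested is meant among the compounds shown, and "the series" means these compounds.

Compound 1 `Cc1c(Cc2ccc(C(F)(F)F)nc2)c[nH]c1C(=O)NC(C)c1cnn(C)c1` was tested in an ADME assay on isolated protein for inhibition of cytochrome P450 2B6 (Homo sapiens), read by HPLC (a higher number here means a weaker inhibitor, a lower number a stronger inhibitor), where compound 1 gives only the assay limit of > 20000 nM rather than a number. Compound 2 `Cc1c(C2(c3ccc(C(F)(F)F)nc3)CC2)c[nH]c1C(=O)NC(C)c1nc[nH]n1` likewise reaches only the limit of > 20000 nM in this assay. Both values therefore sit at the limit of > 20000 nM in this assay, at which 2 of the 2 values shown sit, so compound 1 stands at the edge of what this assay reports. Compound 3 `Cc1c(Cc2ccc(C(F)(F)F)nc2)c[nH]c1C(=O)NC(C)c1cn[nH]c1` differs from compound 1 by hydrogen in place of methyl on an aromatic nitrogen. For the measured compounds named here, no measured pair shows such a step, so little movement beyond the scatter is expected from compound 1 to compound 3 a step that the limit leaves unreadable from compound 1 to compound 3. Compound 3 is estimated at 40000 nM, between 15000 nM and 100000 nM.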

Compound 3, half-maximal inhibitory concentration in the cytochrome P450 2B6 assay: > 20000 nM
Compound 3: only a limit was reported; the forecaster's own chance of this, stated with the estimate: 85%; the middle value does not contradict the limit.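

In the cytochrome P450 2B6 assay compound 1 gives > 20000 nM, which is a limit of the assay. In the cytochrome P450 2B6 assay compound 3 gives > 20000 nM, which is also a limit of the assay. For the compounds shown here, no step between these two compounds can be read: the limit of > 20000 nM in the cytochrome P450 2B6 assay, at which 3 of the 3 values shown sit. The compounds shown leave open whether hydrogen in place of methyl on an aromatic nitrogen changes the result in the cytochrome P450 2B6 assay at all. In a physicochemical assay for solubility, with a stated time of 1 h, at pH 1.6 (a higher number here means a more soluble compound, a lower number a less soluble compound), compound 1 gives 113 ug/mL and compound 3 gives 81 ug/mL, two values within the usual scatter of each other.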